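Nitro Replaces Hydrogen on the Benzoyl Ring of Compound 3

A few compounds are considered here, and "the series" means these few. Any claim that something is new, unique, unknown or untested is made for them only; others in the source may bear on it.

Compound 3 `COc1cc(-c2nnc3n2NC(c2ccco2)C(C(=O)c2ccccc2)S3)cc(OC)c1OC` carries an unsubstituted benzoyl group on the shared core. In a functional assay on MCF7 cells (Homo sapiens) for cytotoxicity, read by MTT assay, with a stated time of 48 h (on this read-out lower numbers stand for stronger inhibition and higher numbers for weaker inhibition), compound 3 gives 39800 nM. Compound 2 `COc1cc(-c2nnc3n2NC(c2ccco2)C(C(=O)c2ccc(C(F)(F)F)cc2)S3)cc(OC)c1OC` gives 33600 nM in this assay, and the step of a 1.2-fold higher number from compound 2 to compound 3 (0.07 log units; within the scatter) leaves the two within the usual scatter. Compound 1 `COc1cc(-c2nnc3n2NC(c2ccco2)C(C(=O)c2ccc(C)cc2)S3)cc(OC)c1OC` gives > 100000 nM in this assay, which is a limit rather than a number (the limit of > 100000 nM in this assay, at which 1 of the 3 values shown sits). For the measured compounds named here, the steps of an at least 2.9-fold lower number from compound 1 to compound 2 (0.47 log units; beyond the scatter) and an at least 2.5-fold lower number from compound 1 to compound 3 (0.40 log units; beyond the scatter) mark the only changes beyond the scatter. Compound 3 thus holds the higher of the two numbers, indistinguishable from compound 2.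

Compound 4 `COc1cc(-c2nnc3n2NC(c2ccco2)C(C(=O)c2ccc([N+](=O)[O-])cc2)S3)cc(OC)c1OC` differs from compound 3 by nitro in place of hydrogen on an aromatic carbon, turning benzoyl into (4-nitrophenyl)carbonyl. Going by the values given here, no measured step exchanges hydrogen for nitro; the changes at this carbon between trifluoromethyl and hydrogen stayed within the scatter, while only methyl gave a distinctly higher number. One therefore expects a step of about a 1.3-fold lower number from compound 3 to compound 4 (0.12 log units; within the scatter) for compound 4, no larger than the scatter. Compound 4 is estimated at 30000 nM, between 10000 nM and 90000 nM.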

Compound 4, half-maximal inhibitory concentration: > 100000 nM
Compound 4: no number, only a limit; the forecaster's own chance of this, stated with the estimate: 15%; at least 3.3-fold (0.52 log units) between middle value and limit.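

At this carbon, only methyl had previously stood apart from hydrogen. Nitro now does so as well, with an at least 2.5-fold higher number from compound 3 to compound 4 (0.40 log units; beyond the scatter), and it also stands apart from trifluoromethyl, with an at least 2.9-fold higher number from compound 2 to compound 4 (0.47 log units; beyond the scatter). Of the three groups placed on this aromatic carbon, para to a large group, only trifluoromethyl stays within the scatter of hydrogen, so a substituent here is not generally tolerated in this assay. Compound 4 gives a limit rather than a number, as compound 1 does, so the step between those two cannot be read: the limit of > 100000 nM in this assay, at which 2 of the 4 values shown sit.

As far as these compounds go, how an amine, a carboxylic acid or chlorine at this carbon would behave remains open. So does whether any group here can give a number distinctly lower than that of compound 3.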